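This account rests on a few compounds, and the source may have more. Where it says the series, first, only, none or still open, it means among the compounds named here.

In an assay on HeLa cells for inhibition of Indoleamine 2,3-dioxygenase 1 (Homo sapiens), read by spectrophotometry, with a stated time of 24 h (a higher number here means that more compound is needed for the effect, a lower number that less compound is needed), compound 1 `NNc1nonc1/C(=N/O)Nc1ccc(F)c(Br)c1` gives 556 nM, and compound 2 `O=S1(=O)CC(Nc2nonc2/C(=N/O)Nc2ccc(F)c(Br)c2)C1` gives 59 nM, the lower of the two numbers shown. Within the data shown here, the one change between them gave a 9.4-fold lower number from compound 1 to compound 2 (0.97 log units; beyond the scatter). Compound 3 `O=S(=O)(CCNc1nonc1/C(=N/O)Nc1ccc(F)c(Br)c1)N1CCC1` differs from compound 2 by a group of 9 heavy atoms (5 carbon, 1 nitrogen, 2 oxygen, 1 sulfur; one four-membered non-aromatic ring with 1 hetero atom) in place of a group of 6 heavy atoms (3 carbon, 2 oxygen, 1 sulfur; one four-membered non-aromatic ring with 1 hetero atom), on a nitrogen on an aromatic ring. Among the measured compounds shown here, only that single measured step bears on this change, and it concerns the same ring nitrogen. Both groups keep a four-membered non-aromatic ring with 1 hetero atom and a sulfur, so only a small step is expected, a 1.2-fold higher number from compound 2 to compound 3 (0.07 log units; within the scatter). Compound 3 is therefore estimated at 70 nM, most likely between 25 nM and 200 nM.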

Compound 3, half-maximal effective concentration: 143 nM
Compound 3: middle estimate off by 2.0-fold (0.31 log units), on the low side, and the stated range covers the measured number.
By their numbers in this assay, from the lowest: compound 2; then compound 3; then compound 1.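

In this assay, the larger 2-((azetidin-1-yl)sulfonyl)ethyl group gives a 2.4-fold higher number from compound 2 to compound 3 (0.38 log units; beyond the scatter) and so loses part of the gain seen with the group in compound 2. Even so, it gives a 3.9-fold lower number from compound 1 to compound 3 (0.59 log units; beyond the scatter) in place of amino, so two different sulfur-containing groups on this nitrogen both give lower numbers than amino. No measured evidence here accounts for the difference between these groups. Open, from the compounds shown here alone, is whether a piperidine in place of the azetidine, or a longer chain before the sulfonyl, would lower the number or raise it.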